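This account rests on a few compounds, and the source may have more. Where it says the series, first, only, none or still open, it means among the compounds named here.

Measured so far in a functional assay on PANC-1 cells (Homo sapiens) for inhibition, read by MTT assay, with a stated time of 72 h; a lower number here means a stronger inhibitor of growth, a higher number a weaker inhibitor of growth:
compound 1 `O=S(=O)(NCCCNCc1ccc(Cl)cc1)c1cc(C(F)(F)F)cc(C(F)(F)F)c1`: 4900 nM
compound 2 `CC(C)(C)c1ccc(CNCCCNS(=O)(=O)c2cc(C(F)(F)F)cc(C(F)(F)F)c2)cc1`: 2500 nM
compound 3 `COc1ccccc1CNCCCNS(=O)(=O)c1cc(C(F)(F)F)cc(C(F)(F)F)c1`: 12000 nM

Compound 3 has the highest number of the three; its nearest neighbour is compound 1 and the furthest is compound 2, both gaps beyond the scatter. Compound 4 `O=S(=O)(NCCCNCc1ccc(Cl)c(Cl)c1)c1cc(C(F)(F)F)cc(C(F)(F)F)c1` is the next member. The change from compound 3: 3,4-dichlorophenyl in place of 2-methoxyphenyl on a saturated chain carbon bound to an amine nitrogen. Going by the values given here, the steps that bear on it are those leading into compound 3 from the other two benzyl variants: a 2.4-fold higher number from compound 1 to compound 3 (0.39 log units; beyond the scatter) and a 4.8-fold higher number from compound 2 to compound 3 (0.68 log units; beyond the scatter). Both show that 2-methoxyphenyl on that carbon carries a modestly higher number than another substituted phenyl, and 3,4-dichlorophenyl is closer in kind to the chloro-bearing compound 1 than to compound 2. A modest drop beyond the scatter is therefore expected for compound 4, a 3.0-fold lower number from compound 3 to compound 4 (0.48 log units; beyond the scatter). For compound 4 the number in this assay is estimated at 4000 nM, within 1500 nM to 12000 nM.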

Compound 4, concentration for 50% growth inhibition: 5600 nM
For compound 4 the middle estimate is 1.4-fold (0.15 log units) below the measured one; measured number inside the range.
By their numbers in this assay, from the lowest: compounds 2, 1 and 4 (each within the scatter of the next, the first and the last beyond it); then compound 3.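

In this assay, chloro in place of hydrogen on an aromatic carbon gives a 1.1-fold higher number from compound 1 to compound 4 (0.06 log units; within the scatter), so this added chloro moves the number by no more than the scatter. At this position, 3,4-dichlorophenyl stays apart from the other two groups, with a 2.1-fold lower number from compound 3 to compound 4 (0.33 log units; beyond the scatter) and a 2.2-fold higher number from compound 2 to compound 4 (0.35 log units; beyond the scatter). No measurement shown accounts for these steps.

Still open, from the compounds shown here alone, is how a 4-methoxyphenyl or 4-trifluoromethylphenyl group would read on that saturated chain carbon. A pyridine ring in place of the phenyl is equally untested by the compounds shown.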